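The source may report more compounds than this note shows. Statements on the series, on what has been measured and on what is new or still open speak of the compounds shown alone.

In a functional assay on HT-29 cells (Homo sapiens) for inhibition, read by CCK-8 assay, with a stated time of 24 h (on this read-out lower numbers stand for stronger inhibition and higher numbers for weaker inhibition), compound 1 (`O=C1Nc2ccccc2/C1=C/c1ccc(-c2cn(-c3cccc(F)c3)nn2)cc1`) gives > 20000 nM as a limit of the assay, not a number. Compound 1 thus offers only a bound as a starting point (the limit of > 20000 nM in this assay, at which 1 of the 2 values shown sits). Compound 2 (`O=C1Nc2ccccc2/C1=C/c1ccc(-c2cn(-c3ccc(F)cc3)nn2)cc1`), which differs from it on the same aromatic nitrogen, gives 17700 nM in this assay as a true number. Among the measured compounds shown here, the one measured step at this place is small (an at least 1.1-fold lower number from compound 1 to compound 2 (0.05 log units; that floor lies within the scatter)) and is the only guide available.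

Compound 3 (`O=C1Nc2ccccc2/C1=C/c1ccc(-c2cn(-c3ccc(Cl)c(C(F)(F)F)c3)nn2)cc1`) is changed at that same place, with 4-chloro-3-(trifluoromethyl)phenyl in place of 3-fluorophenyl on an aromatic nitrogen. For the measured compounds named here, this is a larger exchange than the one leading to compound 2, but with compound 2 at 17700 nM as the only measured number, the data give no firm ground for expecting a large move. In this assay only a modest shift towards a lower number is expected, and no step beyond the scatter can be counted on (an at least 1.5-fold lower number from compound 1 to compound 3 (0.18 log units; that floor lies within the scatter)). Compound 3 is estimated at 13000 nM with 5000 nM to 25000 nM as the expected range, and it may again return only a limit.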

Compound 3, half-maximal inhibitory concentration: 9670 nM
Compound 3: the middle estimate sits 1.3-fold (0.13 log units) above what was measured; low and high end bracket the measured number.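

With 4-chloro-3-(trifluoromethyl)phenyl on the aromatic nitrogen, this position gives its first step that clears the scatter in this assay, as the exchange for 3-fluorophenyl gives an at least 2.0-fold lower number from compound 1 to compound 3 (0.31 log units; beyond the scatter), a size the step to compound 2 did not reach. That step is only a floor, since compound 1 carries a limit of the assay and not a number: the limit of > 20000 nM in this assay, at which 1 of the 3 values shown sits. Set against 4-fluorophenyl, the same group gives a 1.8-fold lower number from compound 2 to compound 3 (0.26 log units; within the scatter), so the data do not separate compound 2 and compound 3, and the gain over compound 1 cannot be credited to the chlorine and trifluoromethyl groups rather than to any exchange that leaves 3-fluorophenyl.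

On these data alone, whether an amine or a carboxylic acid on this phenyl ring, or a longer alkyl chain in place of the ring, would move the number further remains open. Also open, as far as these compounds go, is how much of the step belongs to the chlorine and how much to the trifluoromethyl group, as both enter together in compound 3, and how far compound 1 truly lies from compound 3.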